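Series notes: from 4-butoxyphenyl to 2-methylphenyl on the carbonyl

The compounds below may be only part of what the source reports. "The series", "measured", "known", "first", "only" and "open" are said of these compounds alone.

Of the compounds shown here, two sharing the same core have been read so far in a functional assay on A549 cells (Homo sapiens) for antiproliferative activity, read by MTT assay, with a stated time of 24 h; on this read-out higher numbers stand for weaker inhibition and lower numbers for stronger inhibition. Compound 1 `Cc1cccc(NNC(=O)c2ccc(NS(=O)(=O)c3cnc(O)nc3O)cc2)c1` gives > 20000 nM, which is a limit of the assay and not a number. Within the data shown here, compound 2 `CCCCOc1ccc(C(=O)NNC(=O)c2ccc(NS(=O)(=O)c3cnc(O)nc3O)cc2)cc1` gives 9010 nM, the only actual number so far.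

Compound 3 `Cc1ccccc1C(=O)NNC(=O)c1ccc(NS(=O)(=O)c2cnc(O)nc2O)cc1` has 2-methylphenyl in place of 4-butoxyphenyl on a carbonyl carbon. Among the measured compounds shown here, no measured step sizes this change, so the expectation rests on very little. With compound 2 at 9010 nM as the sole anchor, a small move toward weaker inhibition is expected in this assay, not much beyond the scatter. The expected size and direction are given by a 1.7-fold higher number from compound 2 to compound 3 (0.22 log units; within the scatter). A reading that returns only a limit would also fit this expectation. The estimate for compound 3 is 15000 nM. The expected range for compound 3 runs from 6000 nM to 35000 nM.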

Compound 3, half-maximal inhibitory concentration: 15100 nM
Compound 3: middle estimate off by 1.0-fold (0.00 log units), on the low side; low and high end bracket the measured number.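

In this assay, among these compounds, the first sized step for this place on the carbonyl carbon is a 1.7-fold higher number from compound 2 to compound 3 (0.22 log units; within the scatter), so 2-methylphenyl and 4-butoxyphenyl cannot be told apart here, even though the entering group has fewer heavy atoms and no hydrogen-bond acceptor. The other new comparison is an at least 1.3-fold lower number from compound 1 to compound 3 (0.12 log units; that floor lies within the scatter), so (2-methylphenyl)carbonyl in place of 3-methylphenyl on an amine nitrogen shows no difference that clears the scatter. Compound 1 gives > 20000 nM, which is a limit of the assay and not a number, and its true distance from compound 3 stays unknown because of that limit: the limit of > 20000 nM in this assay, at which 1 of the 3 values shown sits.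

The compounds shown leave open whether any group on this carbonyl carbon can move the number beyond the scatter, for example a phenyl ring carrying an amine or a carboxylic acid, or one with a longer chain than butoxy. They also leave open how much of the step from compound 1 belongs to the carbonyl and how much to the place of the methyl on the ring, as the two travel together in this single comparison.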